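The compounds below may be only part of what the source reports. "The series", "measured", "known", "first", "only" and "open" are said of these compounds alone.

Measured compounds:
- compound 1, `COC(CN(c1ccccc1CO)S(=O)(=O)c1ccccc1N)n1cc(F)c(=O)[nH]c1=O` — in a functional assay on MCF7 cells (Homo sapiens) for antiproliferative activity (a higher number here means a weaker inhibitor, a lower number a stronger inhibitor), compound 1 gives > 100000 nM
- compound 2, `COC(CN(c1ccccc1CO)S(=O)(=O)c1ccccc1[N+](=O)[O-])n1ccc(=O)[nH]c1=O` — in this assay compound 2 gives 64800 nM

The value given for compound 1 is a limit of this assay, not a measured number; (the limit of > 100000 nM in this assay, at which 1 of the 2 values shown sits). Among the compounds with values here, compound 2 holds the only numeric value in the set; the one other entry is that limit. Within the data shown here, compound 1 and compound 2 differ in two places at once, so their pair forms no single step, and their two values show only that compound 1 sits at the limit while compound 2 returns a weak number.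

The next compound, compound 3, `COC(CN(c1ccccc1CO)S(=O)(=O)c1ccccc1[N+](=O)[O-])n1cc(F)c(=O)[nH]c1=O`, is not yet measured. It arises from compound 2 by one change: fluoro in place of hydrogen on an aromatic carbon, on an aromatic carbon of a six-membered aromatic ring with 2 nitrogen, ortho to a group of 1 heavy atom, two atoms from the ring nitrogen, meta to a large group, para to a group of 1 heavy atom. Among the measured compounds shown here, no measured step covers this change. The expected step from compound 2 to compound 3 in this assay is a 1.3-fold higher number from compound 2 to compound 3 (0.12 log units; within the scatter), a small loss if any, not clearly beyond the scatter. Compound 3 is estimated at 85000 nM, within 30000 nM to 200000 nM, with a fair chance that only a limit is reported.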

Compound 3, half-maximal inhibitory concentration: 91000 nM
Beside the measured number, compound 3's estimate is 1.1-fold (0.03 log units) below it; low and high end bracket the measured number.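

In this assay, within the data shown here, the first single-place reading at this position, on an aromatic carbon of a six-membered aromatic ring with 2 nitrogen, two atoms from the ring nitrogen, is a 1.4-fold higher number from compound 2 to compound 3 (0.15 log units; within the scatter); with fluoro in place of hydrogen, the step stays within the scatter, so this pair shows no clear effect of the change. The second single-place reading, for nitro in place of amino on an aromatic carbon, is an at least 1.0-fold lower number from compound 1 to compound 3 (0.04 log units; that floor lies within the scatter); its floor lies within the scatter, so this pair fixes neither a clear gain nor the true size of the step. The entry for compound 1 is a limit of the assay, not a number: the limit of > 100000 nM in this assay, at which 1 of the 3 values shown sits.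

Among these compounds, open is whether a chlorine atom or a methyl group at the fluoro position would give a step beyond the scatter, since hydrogen and fluoro are the only groups compared there. Also open, as far as these compounds go, is whether a carboxylic acid or a methylamino group in place of nitro would give a measured number clearly apart from that of compound 3 in this assay.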